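This account rests on a few compounds, and the source may have more. Where it says the series, first, only, none or still open, it means among the compounds named here.

Measured compounds:
- compound 1, `O=C(O)COC(=O)N(C1CC1)[C@H]1c2ccccc2N(C(=O)c2cccc(F)c2)[C@H]2CC[C@H]21`: 0.8 nM
- compound 2, `O=C(O)CCC(=O)N(C1CC1)C1c2ccccc2N(C(=O)OCc2ccccc2)C2CCC21`: 210 nM

Of the compounds shown here, two have been tested in a functional assay on cells for antagonist activity at prostaglandin D2 receptor 2 (Homo sapiens), read by ELISA, chemiluminescence and cAMP accumulation, with stated times of 10 min and 60 min; on this read-out higher numbers stand for weaker inhibition and lower numbers for stronger inhibition. Compound 1 gives 0.8 nM, the lowest of the two numbers, and so the stronger inhibitor. Compound 2 gives 210 nM, a much higher number that lies well beyond the scatter of the method; the two structures differ in more than one place, so no single change can be read off from that pair.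

Going by the values given here, the unmeasured compound 3, `O=C(O)COC(=O)N(C1CC1)[C@H]1c2ccccc2N(C(=O)c2ccc(OC(F)(F)F)cc2)[C@H]2CC[C@H]21`, keeps the core of compound 1 and changes only one group: 4-(trifluoromethoxy)phenyl in place of 3-fluorophenyl on a carbonyl carbon. The carbonyl carbon that carries it sits on the amide-type nitrogen in a ring, far from the acid chain that both compounds share.

Among the compounds with values here, no pair of measured compounds shows what this particular exchange does in this assay, so the expectation rests on compound 1 alone. The step from compound 1 to compound 3 is expected to be small, a 2.5-fold higher number from compound 1 to compound 3 (0.40 log units; beyond the scatter), perhaps a slight rise in the number and possibly none beyond the scatter. Compound 3 is therefore estimated at 2 nM, within a range from 0.5 nM to 8 nM.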

Compound 3, half-maximal inhibitory concentration: 0.9 nM
Compound 3: the middle estimate sits 2.2-fold (0.35 log units) above what was measured; low and high end bracket the measured number.
By their numbers in this assay, from the lowest: compounds 1 and 3 (each within the scatter of the next); then compound 2.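

In this assay, putting 4-(trifluoromethoxy)phenyl in place of 3-fluorophenyl on the carbonyl carbon, whose other neighbour is the amide-type nitrogen in a ring, gives a 1.1-fold higher number from compound 1 to compound 3 (0.05 log units; within the scatter). This is the first step shown that changes a single place, and it shows that a group of 11 heavy atoms, including a hydrogen-bond acceptor, can replace one of 7 here without moving the number beyond the usual scatter. No measurement at hand explains why the two compounds read alike.

This one exchange alters both the substituent on the aromatic ring and the name-given place it occupies, so it cannot show what either alteration does alone, and the result does not cover everything that might sit on this carbonyl carbon. From the compounds shown here alone, whether the number also holds with a phenyl ring carrying an amine or a carboxylic acid, or with a longer alkyl chain in place of the ring, remains open, as does the effect of the acid chain, which cannot be read from compounds that differ in more than one place.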